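Two diazeniumdiolate groups swapped on a shared dinitro core

This account rests on a few compounds, and the source may have more. Where it says the series, first, only, none or still open, it means among the compounds named here.

Compound 2 `CCN(CC)/[N+]([O-])=N/Oc1cc(O/N=[N+](\[O-])N(C)C)c([N+](=O)[O-])cc1[N+](=O)[O-]` and compound 1 `CCOC(=O)N1CCN(/[N+]([O-])=N/Oc2cc(O/N=[N+](\[O-])N(C)C)c([N+](=O)[O-])cc2[N+](=O)[O-])CC1` share a core and differ only in one group on a double-bonded nitrogen. In a functional assay on HL-60 cells (Homo sapiens) for antiproliferative activity, read by MTT assay, with a stated time of 72 h (a lower number here means a stronger inhibitor, a higher number a weaker inhibitor), compound 2 gives 1000 nM, the lowest of the two numbers here, and compound 1 gives 1200 nM; the step of a 1.2-fold lower number from compound 1 to compound 2 (0.08 log units; within the scatter) lies within the scatter. Compound 3 `CCOC(=O)N1CCN(/[N+]([O-])=N/Oc2cc(O/N=[N+](\[O-])N(CC)CC)c([N+](=O)[O-])cc2[N+](=O)[O-])CC1` has not yet been measured. It keeps the group of compound 2 at the first site and changes the second one: 4-(ethoxycarbonyl)piperazin-1-yl in place of dimethylamino on a double-bonded nitrogen. Among the measured compounds shown here, the only step that bears on it is the one from compound 1 to compound 2, which exchanged the same two kinds of group, in the other direction, without a change beyond the scatter. He therefore expects no step beyond the scatter in this assay, a 1.1-fold higher number from compound 2 to compound 3 (0.04 log units; within the scatter). For compound 3 the estimate is 1100 nM, between 500 nM and 2500 nM.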

Compound 3, half-maximal inhibitory concentration: 2100 nM
Beside the measured number, compound 3's estimate is 1.9-fold (0.28 log units) below it; the range from low to high includes it.
By their numbers in this assay, from the lowest: compounds 2, 1 and 3 (each within the scatter of the next, the first and the last beyond it).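

In this assay, the change at this position gives a 2.1-fold higher number from compound 2 to compound 3 (0.32 log units; beyond the scatter), so 4-(ethoxycarbonyl)piperazin-1-yl in place of dimethylamino on a double-bonded nitrogen has a modest effect, where the earlier exchange of groups stayed within the scatter. The other change here gives a 1.8-fold higher number from compound 1 to compound 3 (0.24 log units; within the scatter), so diethylamino in place of dimethylamino on a double-bonded nitrogen stays within the scatter, and among these compounds only the larger ring-bearing group moves the number beyond it, and only in the step to compound 3. Nothing measured here explains the difference.

These compounds leave open whether the ethyl ester of the piperazine group matters, as a free piperazin-1-yl or a carboxylic acid in its place would show. They also leave open whether a longer chain, such as dipropylamino, would stay within the scatter of diethylamino on this nitrogen.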